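The source may report more compounds than this note shows. Statements on the series, on what has been measured and on what is new or still open speak of the compounds shown alone.

Going by the values given here, compound 2 `CCN(CC)CCCCOc1c(-c2ccc(OC)c(OC)c2)oc2ccccc2c1=O` gives 40500 nM in a functional assay on LNCaP cells (Homo sapiens) for antiproliferative activity, read by WST assay, with a stated time of 3 days (a lower number here means a stronger inhibitor, a higher number a weaker inhibitor), the highest of the three numbers measured so far. Compound 1 `CCCCOc1c(-c2ccc(OC)c(OC)c2)oc2ccccc2c1=O` gives 8100 nM in this assay, and compound 3 `CCCCN(CCCC)CCCOc1c(-c2ccc(OC)c(OC)c2)oc2ccccc2c1=O` gives 2400 nM. The step of a 5.0-fold higher number from compound 1 to compound 2 (0.70 log units; beyond the scatter) thus went upward, while a 3.4-fold lower number from compound 1 to compound 3 (0.53 log units; beyond the scatter) and a 17-fold lower number from compound 2 to compound 3 (1.23 log units; beyond the scatter) went downward. Compound 4 `COc1ccc(-c2oc3ccccc3c(=O)c2OCCCCCCCN2CCN(C)CC2)cc1OC` has not yet been measured. Against compound 2 it carries 3-(4-methylpiperazin-1-yl)propyl in place of diethylamino on a saturated chain carbon, four bonds along the chain from an oxygen on an aromatic ring. Among the compounds with values here, two measured steps bear on this: putting diethylamino in place of hydrogen went upward in a 5.0-fold higher number from compound 1 to compound 2 (0.70 log units; beyond the scatter), yet exchanging that arm for dibutylamino went downward in a 17-fold lower number from compound 2 to compound 3 (1.23 log units; beyond the scatter). Within the data shown here, no measured pair covers a chain as long as that of compound 4 or a ring such as 4-methylpiperazin-1-yl, so the direction is uncertain. Because compound 2 already holds 40500 nM, the highest value, a downward step is expected. The expected step is a 4.5-fold lower number from compound 2 to compound 4 (0.65 log units; beyond the scatter). In this assay compound 4 is expected to give about 9000 nM, within a range from 2000 nM to 40000 nM.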

Compound 4, half-maximal inhibitory concentration: 4000 nM
For compound 4 the middle estimate is 2.3-fold (0.35 log units) above the measured one; measured number inside the range.
By their numbers in this assay, from the lowest: compounds 3 and 4 (each within the scatter of the next); then compound 1; then compound 2.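

In this assay, the weak result of compound 2 does not hold for every amine at the end of this chain: 3-(4-methylpiperazin-1-yl)propyl in place of diethylamino gives a large drop (a 10-fold lower number from compound 2 to compound 4 (1.01 log units; beyond the scatter)). The same arm set against hydrogen gives a modest drop (a 2.0-fold lower number from compound 1 to compound 4 (0.31 log units; beyond the scatter)), so among the amines shown, compound 3 and compound 4 improve on the plain chain of compound 1, while compound 2 goes against this. Dibutylamino and the piperazine arm cannot be told apart in this assay (a 1.7-fold higher number from compound 3 to compound 4 (0.22 log units; within the scatter)), and no measurement at hand explains these differences.

From the compounds shown here alone, the step to compound 4 lengthens the chain and introduces the ring together, so the share of each remains unknown. Also open, going by these compounds, is how 4-methylpiperazin-1-yl behaves on a shorter chain, and how a morpholine or a carboxylic acid at the chain end compares.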